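The compounds below may be only part of what the source reports. "The series", "measured", "known", "first", "only" and "open" are said of these compounds alone.

Measured so far:
- compound 1 `Cn1c(COc2cccc(C(=O)O)c2)nc2ccc(Oc3ccc(Cl)c(F)c3)nc21`: 25.6 10^-6 cm/s
- compound 2 `Cn1c(COc2cccc(C(=O)O)c2)nc2ccc(Oc3ccc(Cl)cn3)cc21`: 16.2 10^-6 cm/s

Going by the values given here, in an ADME assay for permeability, using PAMPA, with a stated time of 4 h (a lower number here means that the compound crosses the layer more slowly, a higher number that the compound crosses the layer faster), compound 2 gives 16.2 10^-6 cm/s and compound 1 gives 25.6 10^-6 cm/s; the only other number in the set is that of compound 1, and the two lie within the usual scatter of each other, so no order can be read between them.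

Compound 3 `Cc1cc(F)cnc1Oc1ccc2nc(COc3cccc(C(=O)O)c3)n(C)c2c1` is not yet measured. Against compound 2 the change is 5-fluoro-3-methylpyridin-2-yl in place of 5-chloropyridin-2-yl on an oxygen on an aromatic ring. Among the compounds with values here, no matched step between measured compounds covers this exchange, and the one other pair in hand shows only two numbers within the scatter, so nothing in the data points to a move beyond the scatter. The expectation for this assay is therefore a step of a 1.1-fold higher number from compound 2 to compound 3 (0.05 log units; within the scatter) of no clear direction, and compound 3 is estimated at 18 10^-6 cm/s, within 10 10^-6 cm/s to 32 10^-6 cm/s.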

Compound 3, apparent permeability: 8.3 10^-6 cm/s
Compound 3: middle estimate off by 2.2-fold (0.34 log units), on the high side; measured number outside the range, below it.
By their numbers in this assay, from the lowest: compounds 3, 2 and 1 (each within the scatter of the next, the first and the last beyond it).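

In this assay, going by these compounds alone, the exchange of 5-chloropyridin-2-yl for 5-fluoro-3-methylpyridin-2-yl on an oxygen on an aromatic ring gives a 2.0-fold lower number from compound 2 to compound 3 (0.29 log units; within the scatter), which provides the first matched step at this position and keeps this exchange within the scatter. Chlorine leaves while fluorine and a methyl enter in the same exchange, so this single step cannot divide any effect between the two parts. Nothing measured here bears on what lies behind the step.

Within the data shown here, still open in this assay is how 5-fluoropyridin-2-yl and 5-chloro-3-methylpyridin-2-yl, each carrying only one part of the exchange, would read against compound 2. Also open, as far as these compounds go, is how a different kind of group on this oxygen, such as an amine-bearing ring or a nitrile-bearing ring, would compare.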